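A few compounds are considered here, and "the series" means these few. Any claim that something is new, unique, unknown or untested is made for them only; others in the source may bear on it.

Of the compounds shown here, three from one series have been tested in a functional assay on 143B cells (Homo sapiens) for inhibition, read by CCK-8 assay, with a stated time of 72 h, tested at 1 uM; on this read-out lower numbers stand for less inhibition and higher numbers for more inhibition at the one concentration tested (going by the name of the read-out). Compound 1 `COc1ccccc1N1C(=O)C(C)SC1c1cccc(C(=O)NCCCCc2ccccc2)c1` gives 61% in this assay. Compound 2 `COc1ccc(OC)c(N2C(=O)CSC2c2cccc(C(=O)NCCCCc3ccccc3)c2)c1` gives 2%, and compound 3 `O=C(NCCCCc1ccccc1)c1cccc(C2OCC(=O)N2c2cccc(F)c2)c1` gives 0%. Among these three numbers compound 2 stands second highest: its number lies within the usual scatter of that of compound 3, so no order between those two can be claimed, while the gap to compound 1 is far beyond the scatter.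

Compound 4 `COc1c(F)cccc1N1C(=O)CSC1c1cccc(C(=O)NCCCCc2ccccc2)c1` has not yet been measured. It differs from compound 2 in one place: 3-fluoro-2-methoxyphenyl in place of 2,5-dimethoxyphenyl on an amide-type nitrogen in a ring. For the measured compounds named here, no pair of measured compounds differs in only one place, so the size of such a step cannot be read off directly. Compound 1, which carries a single methoxy on its aryl group and gives 61%, differs from compound 2 in more than one place, so it offers only loose guidance. A modest rise, beyond the scatter but well short of compound 1, is expected, with a step in this assay of a number 18 percentage points higher from compound 2 to compound 4 (beyond the scatter). Compound 4 is therefore estimated at 20%, with a likely range from 0% to 55%.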

Compound 4, a percentage reported as inhibition, at one concentration (the size of the read-out at that concentration, not a potency): 5%
Estimate against measurement, compound 4: 15 percentage points above, within the range that was stated.
By their numbers in this assay, from the lowest: compounds 3, 2 and 4 (each within the scatter of the next); then compound 1.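

In this assay, for the compounds shown here, placing 3-fluoro-2-methoxyphenyl instead of 2,5-dimethoxyphenyl on the amide-type nitrogen gives the first step that can be read directly, a number 3 percentage points higher from compound 2 to compound 4 (within the scatter). At this one concentration, compound 2 and compound 4 therefore cannot be told apart, even though the entering group has one hydrogen-bond acceptor fewer than the group it replaces. Nothing available offers an explanation for this result.

Going by these compounds, whether another group at this position, such as plain phenyl or 2-aminophenyl, would give a number beyond the scatter remains open. Going by these compounds alone, no single-place step connects compound 1 to the other compounds, so the structural source of the 61% seen for compound 1 also remains unresolved.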